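The compounds below may be only part of what the source reports. "The series", "measured", "known", "first", "only" and "open" are said of these compounds alone.

Measured in a functional assay on HT-29 cells (Homo sapiens) for cytotoxicity, read by MTT assay, with a stated time of 72 h; a higher number here means a weaker inhibitor, a lower number a stronger inhibitor:
- compound 1 `O=C(CN1CCN(c2nnc(Cc3ccncc3)c3ccccc23)CC1)Nc1ccc(Br)cc1`: 1990 nM
- compound 2 `O=C(CN1CCN(c2nnc(Cc3ccncc3)c3ccccc23)CC1)Nc1cc(C(F)(F)F)ccc1Cl`: 4810 nM

Compound 2 has the higher number of the two, which makes it the weaker inhibitor so far. Compound 3 `O=C(CN1CCN(c2nnc(Cc3ccncc3)c3ccccc23)CC1)Nc1ccc(F)c(F)c1` differs from it in one place: 3,4-difluorophenyl in place of 2-chloro-5-(trifluoromethyl)phenyl on an amide-type nitrogen. In other words, 3,4-difluorophenyl replaces 2-chloro-5-(trifluoromethyl)phenyl on an amide-type nitrogen. Among the measured compounds shown here, only one measured step swaps a group at this same place: a 2.4-fold higher number from compound 1 to compound 2 (0.38 log units; beyond the scatter). That modest step is thin evidence, but it suggests a partial return towards compound 1. The expected step is of similar size, downward: a 1.9-fold lower number from compound 2 to compound 3 (0.28 log units; within the scatter). For compound 3 the estimated value is 2500 nM, with an expected range of 1000 nM to 6000 nM.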

Compound 3, half-maximal inhibitory concentration: 2320 nM
Beside the measured number, compound 3's estimate is 1.1-fold (0.03 log units) above it; measured number inside the range.
By their numbers in this assay, from the lowest: compounds 1 and 3 (each within the scatter of the next); then compound 2.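

In this assay, replacing 2-chloro-5-(trifluoromethyl)phenyl with 3,4-difluorophenyl on the amide-type nitrogen gives a 2.1-fold lower number from compound 2 to compound 3 (0.32 log units; beyond the scatter) and so shows that the number at this position can come back down with a different halogen-bearing phenyl. Replacing 4-bromophenyl with 3,4-difluorophenyl gives a 1.2-fold higher number from compound 1 to compound 3 (0.07 log units; within the scatter) and so separates these two groups by no more than normal scatter. Nothing measured here explains these differences.

From the compounds shown here alone, it remains open what an amine or a carboxylic acid on this phenyl ring would do. Going by these compounds, it is also open whether the chlorine or the trifluoromethyl alone would give the number seen for compound 2.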